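The source may hold more compounds than are shown below. What is called first, only, known or untested is meant among the compounds shown, and "the series" means these compounds.

Compound 1 `Nc1cc(-c2ccc(Cl)cc2)nn1-c1cccc(Cl)c1` in a functional assay on Jurkat cells (Homo sapiens) for inhibition, read by MTT assay, with a stated time of 72 h (a higher number here means a weaker inhibitor of growth, a lower number a stronger inhibitor of growth), gives > 100000 nM, a limit of the assay. Compound 3 `Nc1c(C=O)c(-c2ccc(Cl)cc2)nn1-c1cccc(Cl)c1` carries a formyl group on a ring carbon; in this assay compound 3 gives 78900 nM, and the step from the parent is an at least 1.2-fold lower number from compound 1 to compound 3 (0.10 log units; that floor lies within the scatter). Compound 2 `CN(C)/C=N/c1c(C=O)c(-c2ccc(Cl)cc2)nn1-c1ccc(Br)cc1` in this assay gives 38900 nM. Among the numbers shown, compound 3 stands highest of two, with compound 2 nearest and separated by a gap beyond the scatter. Compound 4 `Nc1c(C=O)c(-c2ccc(Cl)cc2)nn1-c1ccc(Br)cc1` differs from compound 3 by 4-bromophenyl in place of 3-chlorophenyl on an aromatic nitrogen. For the measured compounds named here, no measured step covers this exchange; the one measured step, an at least 1.2-fold lower number from compound 1 to compound 3 (0.10 log units; that floor lies within the scatter), concerns the formyl group. Compound 2, which carries the 4-bromophenyl group but also differs at the amino position, shows a lower number than compound 3. Compound 4 is therefore expected to move by a 1.8-fold lower number from compound 3 to compound 4 (0.24 log units; within the scatter) in this assay. Compound 4 is estimated at 45000 nM, ranging from 20000 nM to 100000 nM.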

Compound 4, concentration for 50% growth inhibition: 90700 nM
For compound 4 the middle estimate is 2.0-fold (0.30 log units) below the measured one; measured number inside the range.
By their numbers in this assay, from the lowest: compound 2; then compounds 3 and 4 (each within the scatter of the next). At a limit, above all of these: compound 1.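

In this assay the exchange of 3-chlorophenyl for 4-bromophenyl on the aromatic nitrogen gives a 1.1-fold higher number from compound 3 to compound 4 (0.06 log units; within the scatter), so no effect of this change can be read at this position. Replacing the group of compound 2 on the aromatic carbon with the amino nitrogen gives a 2.3-fold higher number from compound 2 to compound 4 (0.37 log units; beyond the scatter), a modest step that the aryl exchange does not account for. These readings lie close under the upper end of the assay: the limit of > 100000 nM in this assay, at which 1 of the 4 values shown sits.

The exchange alters halogen and ring position together, so 3-bromophenyl would be needed to separate them. As far as these compounds go, whether a carboxylic acid in place of the formyl group changes the picture stays open.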